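The compounds below may be only part of what the source reports. "The series", "measured", "known", "first", "only" and "open" are said of these compounds alone.

In a functional assay on HL-60 cells (Homo sapiens) for cytotoxicity, read by WST assay, with a stated time of 48 h; a lower number here means that less compound is needed, a higher number that more compound is needed for the effect:
- Compound 1 `COc1ccccc1C[C@H]1C(=O)OC[C@@H]1Cc1ccccc1`: 79000 nM
- Compound 2 `O=C1OC[C@H](Cc2ccccc2)[C@H]1Cc1ccccc1OC(F)(F)F`: 39000 nM
- Compound 3 `O=C1OC[C@H](Cc2ccccc2)[C@H]1Cc1cccc(O)c1`: > 100000 nM (a limit of the assay)

Compound 3 has no exact number, because its > 100000 nM is a limit of the assay.

Compound 4 `O=C1OC[C@H](Cc2ccccc2)[C@H]1Cc1cccc(F)c1` has fluoro in place of hydroxy on an aromatic carbon, meta to a large group, so 3-hydroxyphenyl becomes 3-fluorophenyl: fluoro in place of hydroxy on an aromatic carbon.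

Going by the values given here, no measured step covers this swap. The only one available is a 2.0-fold lower number from compound 1 to compound 2 (0.31 log units; beyond the scatter), a modest step in which trifluoromethyl replaces methyl on an oxygen on an aromatic ring. It involves different groups, so it offers only a rough guide to size. Compound 1 at 79000 nM and compound 2 at 39000 nM both carry no hydroxy and both give numbers in this assay. On these few compounds, a modest move to a lower number is expected once the hydroxy leaves.

The estimated change is an at least 1.6-fold lower number from compound 3 to compound 4 (0.22 log units; that floor lies within the scatter).

For compound 4 the expected value is 60000 nM, with an estimated range of 25000 nM to 120000 nM.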

Compound 4, half-maximal effective concentration: 75000 nM
Compound 4: middle estimate off by 1.3-fold (0.10 log units), on the low side; low and high end bracket the measured number.
By their numbers in this assay, from the lowest: compounds 2, 4 and 1 (each within the scatter of the next, the first and the last beyond it). At a limit, above all of these: compound 3.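

In this assay, compound 4 gives the only exact number among the compounds shown with a group at this place on the ring, where 3-fluorophenyl stands in place of 3-hydroxyphenyl. Compound 3 gives > 100000 nM, which is a limit of the assay. The change can be read only as an at least 1.3-fold lower number from compound 3 to compound 4 (0.12 log units; that floor lies within the scatter), because one end of the step is a limit: the limit of > 100000 nM in this assay, at which 1 of the 4 values shown sits.

From the compounds shown here alone, how large the step really is stays open, as does whether swapping hydroxy for fluoro would give a similar step at another place on this aromatic ring. It is also unknown what an amine, a carboxylic acid or a longer chain at this same place would give in this assay.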